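The source may hold more compounds than are shown below. What is called first, only, known or untested is meant among the compounds shown, and "the series" means these compounds.

Measured so far:
- compound 1, `CC(=O)/C(=N\Nc1ccccc1C(F)(F)F)N(C)c1cccc(Cl)c1`: in an assay on isolated protein for binding affinity to corticotropin-releasing factor receptor 1 (Homo sapiens) (a higher number here means a weaker inhibitor, a lower number a stronger inhibitor), compound 1 reaches only the limit of the assay, > 10000 nM.
- compound 2, `CC(=O)/C(=N\Nc1ccccc1Cl)N(C)c1cccc(Cl)c1`: in this assay compound 2 likewise gives only a limit, > 10000 nM.
- compound 3, `COc1cccc(N/C(=N/Nc2ccccc2Cl)C(C)=O)c1`: in this assay compound 3 gives 652 nM.

The change from compound 2 to compound 1 is trifluoromethyl in place of chloro on an aromatic carbon. Its step, a step that the two limits leave unreadable from compound 2 to compound 1, cannot be read, because of the limit of > 10000 nM in this assay, at which 2 of the 3 values shown sit. Compound 4, `COc1cccc(N/C(=N/Nc2ccccc2C(F)(F)F)C(C)=O)c1`, differs from compound 3 by the same change, (trifluoromethyl in place of chloro on an aromatic carbon). How the core of compound 3 differs from that of compound 2 is not broken down here. With the earlier step unreadable, the expectation for compound 4 rests on compound 3 alone, whose affinity is 652 nM. The expected step is a 1.1-fold higher number from compound 3 to compound 4 (0.03 log units; within the scatter). Compound 4 is therefore expected to give about 700 nM, most likely between 200 nM and 3000 nM.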

Compound 4, inhibition constant: 6950 nM
For compound 4 the middle estimate is 9.9-fold (1.00 log units) below the measured one, and the stated range ends below it.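

In this assay the change to trifluoromethyl in place of chloro on an aromatic carbon gives an 11-fold higher number from compound 3 to compound 4 (1.03 log units; beyond the scatter) and so a weaker inhibitor on the core of compound 3. This is a single pair on a single core, so it does not show that the change would have the same effect on any other core. The same change on the core of compound 2 cannot be read, because compound 1 and compound 2 each give only a limit and not a number: the limit of > 10000 nM in this assay, at which 2 of the 4 values shown sit.

The compounds shown leave open how a nitrile or an amine in the same place would compare with chloro and trifluoromethyl. They also leave open whether the step would be of similar size on a further core.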